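The source may hold more compounds than are shown below. What is called first, only, known or untested is meant among the compounds shown, and "the series" means these compounds.

Measured in a functional assay on MNK45 cells (Homo sapiens) for inhibition, read by MTT assay, with a stated time of 48 h; on this read-out higher numbers stand for weaker inhibition and lower numbers for stronger inhibition:
Compound 1 `Cc1ccc(NC(=S)NC(=O)c2ccc(OCc3ccccc3F)cc2)cc1-c1nc2ccccc2[nH]1`: 2420 nM
Compound 2 `Cc1ccc(NC(=S)NC(=O)c2ccc(OCc3cccc(Cl)c3Cl)cc2)cc1-c1nc2ccccc2[nH]1`: > 100000 nM, which is a limit of the assay and not a number.
Compound 3 `Cc1ccc(NC(=S)NC(=O)c2ccc(OCc3cccc(F)c3)cc2)cc1-c1nc2ccccc2[nH]1`: 86800 nM

Among the two numbers shown, compound 3 gives the highest, so the weakest inhibition; the nearest is compound 1, separated by a 36-fold higher number from compound 1 to compound 3 (1.55 log units; beyond the scatter). Compound 4 `Cc1ccc(NC(=S)NC(=O)c2ccc(OCc3ccc(F)cc3)cc2)cc1-c1nc2ccccc2[nH]1` has not yet been measured. It differs from compound 3 in one place: 4-fluorophenyl in place of 3-fluorophenyl on a saturated chain carbon bound to an oxygen on an aromatic ring. For the measured compounds named here, two measured steps concern the same position of the shared core. The change from 2-fluorophenyl to 3-fluorophenyl produced a 36-fold higher number from compound 1 to compound 3 (1.55 log units; beyond the scatter), and the change from 2-fluorophenyl to 2,3-dichlorophenyl produced an at least 41-fold higher number from compound 1 to compound 2 (1.61 log units; beyond the scatter). Between compound 2 and compound 3 there is an at least 1.1-fold lower number from compound 2 to compound 3 (0.06 log units; that floor lies within the scatter). Neither step tests a 4-fluorophenyl group, so the step to compound 4 cannot be read directly from them; what the steps show is that 2-fluorophenyl gives the strongest inhibition here and that the other two groups sit far weaker. A step of a 1.1-fold lower number from compound 3 to compound 4 (0.04 log units; within the scatter) is therefore expected, in no reliable direction. Compound 4 is expected to give about 80000 nM in this assay, with a range from 15000 nM to 100000 nM.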

Compound 4, half-maximal inhibitory concentration: 4220 nM
For compound 4 the middle estimate is 19-fold (1.28 log units) above the measured one, outside the stated range (below it).
By their numbers in this assay, from the lowest: compounds 1 and 4 (each within the scatter of the next); then compound 3. At a limit, above all of these: compound 2.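

The two fluorophenyl groups have the same atoms joined differently, yet 4-fluorophenyl in place of 3-fluorophenyl gives a 21-fold lower number from compound 3 to compound 4 (1.31 log units; beyond the scatter) in this assay, so the place of the fluorine on the ring can by itself decide whether this series inhibits strongly or weakly. The earlier compounds shown here suggested that only 2-fluorophenyl gave strong inhibition, but there is a 1.7-fold higher number from compound 1 to compound 4 (0.24 log units; within the scatter), which places compounds 1 and 4 level and leaves compound 3 as the fluorophenyl compound that stands apart. The dichlorinated group is also left well behind, with an at least 23-fold lower number from compound 2 to compound 4 (1.37 log units; beyond the scatter) as a floor only, since the value for compound 2 is a limit and not a number: the limit of > 100000 nM in this assay, at which 1 of the 4 values shown sits.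

On these data alone, with only these groups at this place, it stays open whether a fluorine on the ring is needed at all, which the plain phenyl group would test, and whether a larger atom behaves in the same way, as 2-chlorophenyl and 4-chlorophenyl would show. The compounds shown also give no explanation of why 3-fluorophenyl differs so sharply from the other two fluorophenyl groups.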